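Trimming the methyl from the acrylamide of compound 2

The compounds below may be only part of what the source reports. "The series", "measured", "known", "first", "only" and "open" are said of these compounds alone.

The measured compounds, in a functional assay on HCT-116 cells (Homo sapiens) for inhibition, read by MTT assay, with a stated time of 48 h; a lower number here means a stronger inhibitor, a higher number a weaker inhibitor:
compound 1, `C/C=C/C(=O)N(Cc1cc(OC)c(OC)c(OC)c1)c1ccc(OC)c(O)c1`, 8450 nM
compound 2, `C=C(C)C(=O)N(Cc1ccc(OC)c(O)c1)c1cc(OC)c(OC)c(OC)c1`, 200 nM
compound 3, `C/C=C/C(=O)N(Cc1ccc(OC)cc1)c1cc(OC)c(OC)c(OC)c1`, 500 nM

Among these three, compound 2 has the lowest number in this assay, and its gaps to both compound 3 and compound 1 are beyond the usual scatter, so on the numbers shown compound 2 is the strongest inhibitor of the set. Compound 3 is the nearest to it; compound 1, which carries a different arrangement of the two aryl groups and a crotonyl amide, is far behind. Among the measured compounds shown here, no single-change pair exists among the measured compounds, so no step size can be read off directly.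

Compound 4, `C=CC(=O)N(Cc1ccc(OC)c(O)c1)c1cc(OC)c(OC)c(OC)c1`, is the unmeasured compound. It differs from compound 2 in one place:

hydrogen in place of methyl on a double-bonded chain carbon bound to a carbonyl carbon

All else in the structure is kept. For the measured compounds named here, with no step to lean on, the expectation is that from compound 2 to compound 4 the change in this assay will be modest, most likely none beyond the scatter or a slight weakening, given by a 1.5-fold higher number from compound 2 to compound 4 (0.18 log units; within the scatter). On that basis compound 4 is estimated at 300 nM, within a range from 100 nM to 900 nM.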

Compound 4, half-maximal inhibitory concentration: 98 nM
For compound 4 the middle estimate is 3.1-fold (0.49 log units) above the measured one; the measured number lies below the stated range.
By their numbers in this assay, from the lowest: compound 4; then compound 2; then compound 3; then compound 1.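

In this assay, among the compounds shown here, this is the first step in the set that can be read from a single change: going from 1-methylethenyl to vinyl gives a 2.0-fold lower number from compound 2 to compound 4 (0.31 log units; beyond the scatter), a modest gain that nonetheless lies beyond the usual scatter. It shows that the methyl on the double-bonded chain carbon bound to a carbonyl carbon is not needed for activity in this assay, and that a single carbon at this place is enough to shift the reading, with the smaller hydrogen giving the stronger inhibitor of this pair. The compounds shown offer no measured property or other finding that would explain this step.

What they leave open is whether the trend is tied to size alone, since one step cannot say how an ethyl group, a fluorine atom or a nitrile at this same carbon would read in this assay. They also leave open whether the double bond itself matters, which a saturated propanoyl amide on the core of compound 4 would address.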